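Fluoro addition on two chromone cores

The compounds below may be only part of what the source reports. "The series", "measured", "known", "first", "only" and "open" are said of these compounds alone.

The measure throughout is a functional assay on PC-3 cells (Homo sapiens) for inhibition, read by sulforhodamine B assay, with a stated time of 48 h; a lower number here means a stronger inhibitor, a higher number a weaker inhibitor. Compound 1 `O=c1c(C2N=C(c3ccccc3)SS2)coc2cc(Cl)ccc12` gives 38400 nM. Compound 2 `O=c1c(C(=S)Nc2ccccc2)coc2ccccc12` gives 60600 nM; these two numbers lie within the scatter of each other, so no order is drawn between them. Compound 3 `O=c1c(C(=S)Nc2ccccc2)coc2ccc(F)cc12` reaches only a limit of the assay, > 100000 nM, and is not a number.

Going by the values given here, the one measured step is an at least 1.6-fold higher number from compound 2 to compound 3 (0.21 log units; that floor lies within the scatter), made by fluoro in place of hydrogen on an aromatic carbon; its size rests on (the limit of > 100000 nM in this assay, at which 1 of the 3 values shown sits), so only a floor is known. How the core of compound 1 differs from the core of compound 2 is not broken down here.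

Compound 4 `O=c1c(C2N=C(c3ccccc3)SS2)coc2cc(Cl)c(F)cc12` is not yet measured. It differs from compound 1 by fluoro in place of hydrogen on an aromatic carbon. The surroundings are not identical to those of the measured step: in compound 4 the entering fluoro sits ortho to a chloro group, which the pair of compound 2 and compound 3 lacks, so this is the same kind of change rather than the same change.

The expected step from compound 1 to compound 4 is a 1.7-fold higher number from compound 1 to compound 4 (0.23 log units; within the scatter), set beside the measured step of an at least 1.6-fold higher number from compound 2 to compound 3 (0.21 log units; that floor lies within the scatter). In this assay compound 1 gives 38400 nM, and the estimate starts from that value. The measured step is known only as a floor, given by the limit of > 100000 nM in this assay, at which 1 of the 3 values shown sits. Compound 4 is therefore estimated at 65000 nM, with a range from 25000 nM to 160000 nM.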

Compound 4, half-maximal inhibitory concentration: 56900 nM
For compound 4 the middle estimate is 1.1-fold (0.06 log units) above the measured one; low and high end bracket the measured number.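

In this assay, fluoro in place of hydrogen on an aromatic carbon of the core of compound 1 gives a 1.5-fold higher number from compound 1 to compound 4 (0.17 log units; within the scatter), so no order is drawn between these two compounds. Set beside the same change on the other core, the two steps give no sign of a difference between the cores, but they do not settle the matter: the same change on two cores in this assay, an at least 1.6-fold higher number (0.21 log units; that floor lies within the scatter) from compound 2 to compound 3 and a 1.5-fold higher number (0.17 log units; within the scatter) from compound 1 to compound 4; the limit leaves it open whether they differ. This does not show that the change carries from one core to the other with the same size, since the step on the core of compound 1 stays within the scatter and the step on the other core is known only as a floor, which rests on a single limit: the limit of > 100000 nM in this assay, at which 1 of the 4 values shown sits.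

The compounds shown leave open whether the chloro group ortho to the entering fluoro, present in compound 4 and absent from compound 3, has any bearing on the step. They also leave open whether a group other than fluoro at this place, such as an amine, a methoxy group or a carboxylic acid, would give a step that clears the scatter on either core.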